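Pyrazole series: carbamate in place of the pyridylmethyl amide

The compounds below may be only part of what the source reports. "The series", "measured", "known", "first", "only" and "open" are said of these compounds alone.

Three compounds carry the same core, a five-membered aromatic ring with 2 nitrogen bearing a methyl group and a benzylic arm, and differ in the group on the remaining aromatic carbon and on the arm. In an assay on CHO-K1 cells for displacement of a labelled ligand from prostaglandin E2 receptor EP1 subtype (Homo sapiens) (a higher number here means a weaker inhibitor, a lower number a stronger inhibitor), compound 1 `Cc1cc(C(=O)O)nn1Cc1cc(Br)ccc1OCc1ccccc1` gives 6.31 nM, compound 2 `Cc1cc(C(=O)NCc2ccncc2)nn1Cc1cc(Cl)ccc1OCc1ccccc1` gives 79.4 nM, and compound 3 `Cc1cc(C(=O)NN2CCOCC2)nn1Cc1cc(Cl)ccc1OCC(C)C` gives 251 nM. Compound 2 therefore holds the second highest number of the three: compound 3 sits above it, beyond the scatter, and compound 1 sits below it, also beyond the scatter. Within the data shown here, no pair of these three differs in one place only, so no single-point step is available.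

Compound 4 `CCOC(=O)Nc1cc(C)n(Cc2cc(Cl)ccc2OCc2ccccc2)n1` is not yet measured. It differs from compound 2 as follows ((ethoxycarbonyl)amino in place of ((pyridin-4-yl)methyl)carbamoyl on an aromatic carbon). The bromo-to-chloro and the benzyloxy arm are the same as in compound 2, so the comparison rests on the exchange at the aromatic carbon alone.

Compound 1, with a free carboxylic acid at that carbon, gives the lowest number seen, and both compounds carrying a larger group there give higher numbers. For compound 4 a modestly higher number than compound 2 is expected, a step of a 2.0-fold higher number from compound 2 to compound 4 (0.30 log units; within the scatter), near the edge of the scatter. The estimate for compound 4 in this assay is 160 nM, within 35 nM to 750 nM.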

Compound 4, half-maximal inhibitory concentration: 79.4 nM
Compound 4: the middle estimate sits 2.0-fold (0.30 log units) above what was measured; the range from low to high includes it.
By their numbers in this assay, from the lowest: compound 1; then compounds 2 and 4 (each within the scatter of the next); then compound 3.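

In this assay, among these compounds, the step from the ((pyridin-4-yl)methyl)carbamoyl group to the (ethoxycarbonyl)amino group on this aromatic carbon reads no change at the digits printed from compound 2 to compound 4 (within the scatter), the first comparison that isolates this position. The position therefore accepts an exchange from 10 heavy atoms with a six-membered aromatic ring to 6 heavy atoms with no ring, and the pyridine ring is not required to hold the value in this pair, even though the attachment to the aromatic carbon also changes from the carbonyl carbon to a nitrogen. Nothing available explains why the two groups read alike, and the shared counts of hydrogen-bond donors and acceptors are only an observation.

A benzyl amide at this carbon would separate the contribution of the pyridine nitrogen from that of the ring itself, and a plain amine would show whether the carbonyl-bearing part of either group matters at all. A butoxycarbonylamino group would test how much longer the chain on the carbamate can become at this position.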